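Swapping the Furanyl Group for an Arylsulfanyl Group

The source may hold more compounds than are shown below. What is called first, only, known or untested is meant among the compounds shown, and "the series" means these compounds.

Two acylguanidines share a core that carries a methyl group and a methylsulfonyl group. Compound 1 `Cc1cc(F)c(S(C)(=O)=O)cc1C(=O)N=C(N)N` bears a fluoro substituent and in a functional assay for inhibition of sodium/hydrogen exchanger (Oryctolagus cuniculus) (a lower number here means a stronger inhibitor, a higher number a weaker inhibitor), compound 1 gives 44 nM. Compound 2 `Cc1cc(-c2ccco2)c(S(C)(=O)=O)cc1C(=O)N=C(N)N` carries a furan-2-yl group instead, and in this assay compound 2 gives 16 nM. The step of a 2.8-fold lower number from compound 1 to compound 2 (0.44 log units; beyond the scatter) is the only measured one; compound 2 therefore holds the lowest of the two numbers shown. Compound 3 `Cc1cc(Sc2cccc(Cl)c2)c(S(C)(=O)=O)cc1C(=O)N=C(N)N` differs from compound 2 by (3-chlorophenyl)sulfanyl in place of furan-2-yl on an aromatic carbon. Among the measured compounds shown here, no measured step bears directly on this exchange, since the one known step replaced fluoro with furan-2-yl rather than one ring-bearing group with another. Compound 3 is therefore expected to stay close to compound 2, with the step of a 1.3-fold higher number from compound 2 to compound 3 (0.10 log units; within the scatter) estimated to lie within the scatter. The value of compound 3 in this assay is estimated at 20 nM, within a range from 6 nM to 70 nM.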

Compound 3, half-maximal inhibitory concentration: 37 nM
Compound 3: middle estimate off by 1.9-fold (0.27 log units), on the low side; the range from low to high includes it.
By their numbers in this assay, from the lowest: compound 2; then compounds 3 and 1 (each within the scatter of the next).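

At the position ortho to a methylsulfonyl group, this assay shows that the lower number seen with furan-2-yl does not carry over to every ring-bearing group: (3-chlorophenyl)sulfanyl gives a 2.3-fold higher number from compound 2 to compound 3 (0.36 log units; beyond the scatter). Set against fluoro, the same group gives a 1.2-fold lower number from compound 1 to compound 3 (0.08 log units; within the scatter), so a ring at this carbon does not in itself lower the number: compound 2 fits that idea and compound 3 goes against it. Nothing available explains the difference between the two ring-bearing groups.

Going by these compounds, it remains open whether the sulfur link or the chlorine on the ring goes with the step from furan-2-yl. On these data alone, it is also open how a plain phenyl group or an amine at this carbon would read in this assay.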